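The source may report more compounds than this note shows. Statements on the series, on what has been measured and on what is new or still open speak of the compounds shown alone.

Compound 3 `CC1=C(/C=C/C(C)=C/C=C/C(C)=C\C(=O)NCc2ccc(O)cc2)C(C)(C)CCC1n1ccnc1` is one of three retinoid-like amides sharing a common core and differing only in the group on the amide nitrogen. In a functional assay on MDA-MB-468 cells (Homo sapiens) for inhibition, read by MTT assay (on this read-out higher numbers stand for weaker inhibition of growth and lower numbers for stronger inhibition of growth), compound 3 gives 2700 nM, which stands second highest of the three numbers: compound 1 `CC1=C(/C=C/C(C)=C/C=C/C(C)=C\C(=O)NCc2ccc(F)cc2)C(C)(C)CCC1n1ccnc1` gives 2450 nM, and compound 2 `CC1=C(/C=C/C(C)=C/C=C/C(C)=C\C(=O)Nc2ccc(F)cc2)C(C)(C)CCC1n1ccnc1` gives 4570 nM, so that compound 3 sits closest to compound 1 and furthest from compound 2, every gap among them lying within the scatter.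

Compound 4 `CC1=C(/C=C/C(C)=C/C=C/C(C)=C\C(=O)Nc2ccccc2)C(C)(C)CCC1n1ccnc1` differs from compound 3 by phenyl in place of 4-hydroxybenzyl on an amide-type nitrogen. Going by the values given here, two measured steps bear on it. The change from a benzyl-type to a phenyl-type group gave a 1.9-fold higher number from compound 1 to compound 2 (0.27 log units; within the scatter), and the reverse change with the hydroxy group gave a 1.7-fold lower number from compound 2 to compound 3 (0.23 log units; within the scatter). Swapping hydroxy for fluoro gave a 1.1-fold higher number from compound 1 to compound 3 (0.04 log units; within the scatter), so the para substituent itself hardly moves the number. A modest rise toward the value of compound 2 is therefore expected for compound 4, giving a 1.6-fold higher number from compound 3 to compound 4 (0.19 log units; within the scatter). The estimate for compound 4 in this assay is 4200 nM, with a range from 1900 nM to 9500 nM.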

Compound 4, concentration for 50% growth inhibition: 2540 nM
The estimate for compound 4 lay 1.7-fold (0.22 log units) above the measured number; measured number inside the range.
By their numbers in this assay, from the lowest: compounds 1, 4, 3 and 2 (each within the scatter of the next).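

In this assay, phenyl in place of 4-hydroxybenzyl on the amide-type nitrogen gave a 1.1-fold lower number from compound 3 to compound 4 (0.03 log units; within the scatter) and phenyl in place of 4-fluorobenzyl gave a 1.0-fold higher number from compound 1 to compound 4 (0.02 log units; within the scatter) at the same position. Hydrogen in place of fluoro on the phenyl ring gave a 1.8-fold lower number from compound 2 to compound 4 (0.26 log units; within the scatter), so the unsubstituted phenyl amide is not set apart from the two benzyl amides, and a phenyl-type group on this nitrogen does not by itself separate the compounds. All four compounds now lie within the scatter of one another, and nothing shown offers a reason for this flat picture.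

The compounds shown carry only benzyl-type and phenyl-type groups on this nitrogen. As far as these compounds go, how an amine, a carboxylic acid or a longer alkyl chain there would read, and whether any group at this position moves the number beyond the scatter, stays open.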